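The source may report more compounds than this note shows. Statements on the series, on what has been measured and on what is new or still open speak of the compounds shown alone.

Among the measured compounds shown here, in an ADME assay on BCBL1 cells (Homo sapiens) for cytotoxicity, with a stated time of 7 days (on this read-out lower numbers stand for higher toxicity in this test and higher numbers for lower toxicity in this test), all three compounds measured so far stop at the same limit. Compound 1 `CCCCSc1nc(N)nc2c1ncn2/C=C1/CC1(CO)CO` returns only the limit > 20000 nM in this assay. Compound 2 `CCCCCOc1nc(N)nc2c1ncn2/C=C1/CC1(CO)CO` likewise returns only the limit > 20000 nM. Compound 3 `CCCCCCCCSc1nc(N)nc2c1ncn2/C=C1/CC1(CO)CO` also returns only the limit > 20000 nM, so it stands level with the other two on the numbers available, and this is where the limit of > 20000 nM in this assay, at which 3 of the 3 values shown sit, places it. None of the three steps between them can be sized: the step that the two limits leave unreadable from compound 1 to compound 2 is unreadable, as is a step that the two limits leave unreadable from compound 1 to compound 3 and a step that the two limits leave unreadable from compound 2 to compound 3.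

Compound 4 `Nc1nc(OCc2ccccc2)c2ncn(/C=C3/CC3(CO)CO)c2n1` has not yet been measured. Compared with compound 3 it differs as follows: benzyloxy in place of octylsulfanyl on an aromatic carbon. The three unreadable steps are the only ones that bear on this change, and they show that exchanging one chain on this aromatic carbon for another, whether through sulfur or through oxygen and whether of four, five or eight chain carbons, left every compound at the limit. On that basis compound 4 is expected to give 25000 nM in this assay, within 10000 nM to 60000 nM, and most likely to be reported as a limit again. The step that the limit leaves unreadable from compound 3 to compound 4 is therefore estimated to stay within the scatter, with no direction expected.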

Compound 4, half-maximal cytotoxic concentration: > 20000 nM
Compound 4: a limit, no number (the forecaster's own chance of this, stated with the estimate: 80%); the middle value does not contradict the limit.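

In this assay compound 4 gives > 20000 nM, which is a limit and not a number, so none of its steps to compound 1, compound 2 or compound 3 can be read. All four compounds share one position: the limit of > 20000 nM in this assay, at which 4 of the 4 values shown sit. The compounds shown leave open what change at this aromatic carbon, if any, would give a measurable half-maximal cytotoxic concentration.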